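This account rests on a few compounds, and the source may have more. Where it says the series, first, only, none or still open, it means among the compounds named here.

Measured so far in a physicochemical assay for solubility; on this read-out lower numbers stand for lower solubility and higher numbers for higher solubility
- compound 1 `CS(=O)(=O)c1cnc(Nc2ccc(O)cc2)nc1NCc1ccccc1` gives 27000 nM
- compound 2 `CN(Cc1ccc2nccn2c1)c1nnc(-c2ccc(-c3ccccc3Cl)nc2)o1` gives 10000 nM
- compound 3 `CNC(=O)c1sc(N2CC3CC2(CNC(=O)c2c[nH]c4ncc(C(F)(F)F)cc24)C3)nc1C(F)(F)F` gives < 1600 nM

Compound 1 and compound 2 have actual numbers. The entry for compound 3 (< 1600 nM) is a limit of the assay and not a number. That entry is the limit of < 1600 nM in this assay, at which 1 of the 3 values shown sits.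

Compound 4 `CNC(=O)c1sc(N2CC3CC2(CNC(=O)c2c[nH]c4ncc(Cl)cc24)C3)nc1C(F)(F)F` has chloro in place of trifluoromethyl on an aromatic carbon of a six-membered aromatic ring with 1 nitrogen, part of a fused or bridged system of two rings (chloro in place of trifluoromethyl on an aromatic carbon). Going by the values given here, no measured pair here shows what this exchange does in this assay, and compound 3 offers no exact starting number. A small upward move, close to the usual scatter, is therefore expected for an at least 1.1-fold higher number from compound 3 to compound 4 (0.05 log units; that floor lies within the scatter). For compound 4 the estimate is 1800 nM, with an expected range from 600 nM to 5000 nM.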

Compound 4, solubility: 2000 nM
Estimate against measurement, compound 4: 1.1-fold (0.05 log units) below; the measured number falls inside the stated range.
By their numbers in this assay, from the lowest: compound 4; then compound 2; then compound 1. At a limit, below all of these: compound 3.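

Chloro in place of trifluoromethyl on an aromatic carbon gives a first reading for this change in this assay, with an at least 1.2-fold higher number from compound 3 to compound 4 (0.09 log units; that floor lies within the scatter). Compound 3 stands at a limit of the assay and not at a number: the limit of < 1600 nM in this assay, at which 1 of the 4 values shown sits. The step therefore gives only a floor. Compound 4 now provides an actual number for this series, 2000 nM.

From the compounds shown here alone, how far compound 4 truly lies from compound 3 stays open. So does the reading in this assay with a methoxy group or an amine on this aromatic carbon.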